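This account rests on a few compounds, and the source may have more. Where it says the series, first, only, none or still open, it means among the compounds named here.

Measured compounds:
- compound 1, `COc1c(Br)cc(Br)cc1C(=O)Nc1ccccc1`: in an assay on isolated protein for inhibition of thiosulfate sulfurtransferase (Homo sapiens), with a stated time of 60 min, in the absence of a further agent (on this read-out higher numbers stand for weaker inhibition and lower numbers for stronger inhibition), compound 1 gives > 100000 nM, which is a limit of the assay rather than a number.
- compound 2, `O=C(Nc1ccccc1)c1cccc(Br)c1`: in this assay compound 2 gives > 100000 nM, again a limit of the assay and not a number.

Compound 2 therefore has no measured value on which to stand; it sits at the limit, and both values shown so far sit there (the limit of > 100000 nM in this assay, at which 2 of the 2 values shown sit). Nothing between the two measured compounds can be read as a step, since neither carries a number, and compound 1 differs from compound 2 in more than one place.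

Compound 3, `O=C(Nc1ccccc1)c1cc(Br)cc(Br)c1`, differs from compound 2 by bromo in place of hydrogen on an aromatic carbon. With compound 1, which also carries two bromo groups on its core, at the limit as well, no step beyond the scatter is anticipated in this assay, in either direction. The expected step is a step that the limit leaves unreadable from compound 2 to compound 3. Compound 3 is estimated at 200000 nM, with a range from 100000 nM to 1000000 nM, most likely reported again only as a limit.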

Compound 3, half-maximal inhibitory concentration: > 100000 nM
Compound 3 was reported as a limit (the forecaster's own chance of this, stated with the estimate: 85%); the middle value does not contradict the limit.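

In this assay compound 3 gives > 100000 nM, a limit of the assay and not a number. No step to compound 3 can be read from compound 1 or compound 2, because all three compounds stand at the same limit: the limit of > 100000 nM in this assay, at which 3 of the 3 values shown sit.

The compounds shown leave open whether any compound with this shared core gives a readable value in this assay.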